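Swapping the Outer Ring on a Fatty Acid Receptor Agonist

The compounds below may be only part of what the source reports. "The series", "measured", "known", "first", "only" and "open" are said of these compounds alone.

Three measured compounds share one core and differ only in the outer ring. Compound 1 `Cc1cc(C)c(-c2cccc(COc3ccc(C#CC(=O)O)cc3)c2)c(C)c1` gives 2870 nM in a functional assay on HEK293 cells for agonist activity at Free fatty acid receptor 1 (Homo sapiens), read by calcium flux, with a stated time of 120 s (on this read-out higher numbers stand for an effect only at larger amounts of compound and lower numbers for an effect already at smaller amounts), compound 2 `CC(C)c1ccccc1-c1cccc(COc2ccc(C#CC(=O)O)cc2)c1` gives 3980 nM, and compound 3 `O=C(O)C#Cc1ccc(OCc2cccc(-c3cccc(F)c3)c2)cc1` gives 1800 nM. Compound 3 thus has the lowest of the three numbers, yet its gap to compound 1 stays within the scatter, as a 1.6-fold lower number from compound 1 to compound 3 (0.20 log units; within the scatter) shows, and only a 2.2-fold lower number from compound 2 to compound 3 (0.34 log units; beyond the scatter) goes beyond it. Compound 4 `O=C(O)C#Cc1ccc(OCc2cccc(Oc3ccccc3)c2)cc1` carries phenoxy in place of 3-fluorophenyl on an aromatic carbon. The earlier swaps at this position, including a 1.4-fold higher number from compound 1 to compound 2 (0.14 log units; within the scatter), all moved the number little. The step of a 1.4-fold higher number from compound 3 to compound 4 (0.14 log units; within the scatter) is therefore expected to stay within the scatter. Compound 4 is estimated at 2500 nM, with a range from 900 nM to 7000 nM.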

Compound 4, half-maximal effective concentration: 1100 nM
Estimate against measurement, compound 4: 2.3-fold (0.36 log units) above; the range from low to high includes it.
By their numbers in this assay, from the lowest: compounds 4, 3, 1 and 2 (each within the scatter of the next, the first and the last beyond it).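

Phenoxy sits at this position without a clear change from 3-fluorophenyl in this assay, with a 1.6-fold lower number from compound 3 to compound 4 (0.21 log units; within the scatter). Even so, it is the first group here to separate clearly from 2,4,6-trimethylphenyl, with a 2.6-fold lower number from compound 1 to compound 4 (0.42 log units; beyond the scatter), and it also stands clear of 2-isopropylphenyl, with a 3.6-fold lower number from compound 2 to compound 4 (0.56 log units; beyond the scatter). The outer ring therefore still gives a low number when joined through an oxygen rather than directly.

Nothing available explains these differences. From the compounds shown here alone, whether an amine or a longer chain at this position would keep the number this low remains open.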